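The compounds below may be only part of what the source reports. "The series", "measured", "known", "first", "only" and "open" are said of these compounds alone.

In an ADME assay on MT4 cells (Homo sapiens) for cytotoxicity, read by MTT assay (on this read-out lower numbers stand for higher toxicity in this test and higher numbers for lower toxicity in this test), compound 1 (`O=C(CSc1nncnc1-c1cccc2ccccc12)Nc1ccc(Cl)cc1Cl`) gives 254000 nM. Compound 3 (`CCOC(=O)c1ccc(NC(=O)CSc2nncnc2-c2cccc3ccccc23)c(Cl)c1`) gives 150000 nM, which lies within the scatter of that number. Compound 2 (`Cc1ccc(NC(=O)CSc2nncnc2-c2ccccc2Cl)c(Br)c1`) gives 45000 nM, a clearly lower number than that of compound 1.

Compound 4 (`Cc1ccc(NC(=O)CSc2nncnc2-c2cccc3ccccc23)c([N+](=O)[O-])c1`) keeps the core of compound 1 and has not yet been measured in this assay. Its change is 4-methyl-2-nitrophenyl in place of 2,4-dichlorophenyl on an amide-type nitrogen.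

Among the compounds with values here, one measured step bears on this change, and only in part, since it replaces a single chloro and not the whole group. That step is a 1.7-fold lower number from compound 1 to compound 3 (0.23 log units; within the scatter), and it stays within the scatter. Within the data shown here, no measured step shows the effect of a nitro or methyl group here, so the expectation is weak. A small move to a lower number is expected, and the expected step is a 1.8-fold lower number from compound 1 to compound 4 (0.26 log units; within the scatter). For compound 4 the estimated value is 140000 nM, with an expected range from 45000 nM to 300000 nM.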

Compound 4, half-maximal cytotoxic concentration: 147000 nM
Beside the measured number, compound 4's estimate is 1.1-fold (0.02 log units) below it; the range from low to high includes it.
By their numbers in this assay, from the lowest: compound 2; then compounds 4, 3 and 1 (each within the scatter of the next).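

In this assay the exchange of the whole 2,4-dichlorophenyl on the amide-type nitrogen for 4-methyl-2-nitrophenyl gives a 1.7-fold lower number from compound 1 to compound 4 (0.24 log units; within the scatter) and so stays within the scatter. The earlier step replaced a single chloro, whereas here both chloro groups leave and the number still does not move beyond the scatter. At this position, then, the chloro groups are not required to keep the number within the scatter of compound 1 in this test, and nothing shown gives a reason for this result.

On these data alone, the methyl and nitro groups enter together, so what each contributes alone stays open. Also open, as far as these compounds go, is whether an amine or a carboxylic acid on this ring would leave the number within the scatter as well.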